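A few compounds are considered here, and "the series" means these few. Any claim that something is new, unique, unknown or untested is made for them only; others in the source may bear on it.

Measured so far in an ADME assay on BJ cells (Homo sapiens), read by MTT assay, with a stated time of 72 h; on this read-out higher numbers stand for weaker inhibition and lower numbers for stronger inhibition:
compound 1 `COc1ncnc2c1c(-c1ccccc1)cn2[C@@H]1O[C@H](CO)[C@@H](O)[C@H]1O`: > 100000 nM
compound 2 `O=c1[nH]cnc2c1c(-c1cc3ccccc3o1)cn2[C@@H]1O[C@H](CO)[C@@H](O)[C@H]1O`: 62700 nM
compound 3 `COc1ncnc2c1c(-c1cc3ccccc3o1)cn2[C@@H]1O[C@H](CO)[C@@H](O)[C@H]1O`: 22400 nM

The value for compound 1 is a limit of the assay, not a number (the limit of > 100000 nM in this assay, at which 1 of the 3 values shown sits). Of the two numbers, compound 2 gives the higher one.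

Compound 4 `O=c1[nH]cnc2c1c(-c1ccccc1)cn2[C@@H]1O[C@H](CO)[C@@H](O)[C@H]1O` is not yet measured in this assay. It differs from compound 2 by phenyl in place of 1-benzofuran-2-yl on an aromatic carbon. The same change, at the same place, runs from compound 3 to compound 1 (phenyl in place of 1-benzofuran-2-yl on an aromatic carbon), where it gave an at least 4.4-fold higher number from compound 3 to compound 1 (0.64 log units; beyond the scatter). How the core of compound 2 differs from the core of compound 3 is not broken down here.

The expected step for compound 4 is a 3.2-fold higher number from compound 2 to compound 4 (0.50 log units; beyond the scatter), resting on an at least 4.4-fold higher number from compound 3 to compound 1 (0.64 log units; beyond the scatter). Since compound 2 already starts from 62700 nM, compound 4 is estimated at 200000 nM, within 70000 nM to 600000 nM. Compound 4 is expected to come out as a limit of the assay rather than a number.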

Compound 4, half-maximal inhibitory concentration: > 100000 nM
Compound 4: a limit, no number (the forecaster's own chance of this, stated with the estimate: 75%); the middle value is on the limit's open side.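

In this assay, compound 4 gives > 100000 nM, a limit of the assay and not a number. On the core of compound 2, phenyl in place of 1-benzofuran-2-yl gives an at least 1.5-fold higher number from compound 2 to compound 4 (0.20 log units; that floor lies within the scatter), a floor that does not by itself establish a true rise on this core. The result is compatible with the change carrying over from one core to the other, but it does not show that the change has the same size on both: the same change on two cores in this assay, an at least 4.4-fold higher number (0.64 log units; beyond the scatter) from compound 3 to compound 1 and an at least 1.5-fold higher number (0.20 log units; that floor lies within the scatter) from compound 2 to compound 4; the limit leaves it open whether they differ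

On these data alone, how far the phenyl compounds lie past the limit remains open: the limit of > 100000 nM in this assay, at which 2 of the 4 values shown sit. Also open is how another group on the same aromatic carbon, such as an amine or a carboxylic acid, would read in this assay.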